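The source may report more compounds than this note shows. Statements on the series, on what has been measured and on what is new or still open speak of the compounds shown alone.

Measured compounds:
compound 1 `COc1cccc(CNc2ncnc3c2ncn3C2CCCCO2)c1` — in an ADME assay on BJ cells (Homo sapiens) for cytotoxicity, read by MTT assay, with a stated time of 72 h (on this read-out lower numbers stand for stronger inhibition and higher numbers for weaker inhibition), compound 1 gives > 100000 nM, which is a limit of the assay.
compound 2 `COc1ccc(CNc2ncnc3c2ncn3C2CCCCO2)cc1` — in this assay compound 2 gives > 100000 nM, again a limit.
compound 3 `COc1cccc(CNc2ncnc3c2ncn3C2CCCO2)c1` — in this assay compound 3 gives > 100000 nM, again a limit.

Compound 1 and compound 2 differ by 4-methoxyphenyl in place of 3-methoxyphenyl on a saturated chain carbon bound to a nitrogen on an aromatic ring, and the step that the two limits leave unreadable from compound 1 to compound 2. The cores of compound 1 and compound 3 differ by oxolan-2-yl in place of oxan-2-yl on an aromatic nitrogen, and the step that the two limits leave unreadable from compound 1 to compound 3. All three values sit at the limit of > 100000 nM in this assay, at which 3 of the 3 values shown sit.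

Compound 4 `COc1ccc(CNc2ncnc3c2ncn3C2CCCO2)cc1` is not yet measured. It differs from compound 3 by 4-methoxyphenyl in place of 3-methoxyphenyl on a saturated chain carbon bound to a nitrogen on an aromatic ring, the same change as that from compound 1 to compound 2, at the same place. From compound 3 to compound 4 the expected step is a step that the limit leaves unreadable from compound 3 to compound 4. Among the compounds with values here, this expectation rests on compound 1 and compound 2 both sitting at the limit of > 100000 nM in this assay, at which 3 of the 3 values shown sit, so that a step that the two limits leave unreadable from compound 1 to compound 2 is the only comparison available. Compound 4 is expected at 150000 nM, within 60000 nM to 400000 nM, most probably reported once more as a limit.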

Compound 4, half-maximal inhibitory concentration: > 100000 nM
Compound 4 ended at the assay's limit; the forecaster's own chance of this, stated with the estimate: 90%; the middle value lies beyond the limit too.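

Compound 4 also gives only an assay limit, so neither its step from compound 3 nor its step from compound 2 can be read: the limit of > 100000 nM in this assay, at which 4 of the 4 values shown sit.

Whether either the 4-methoxyphenyl or the oxolan-2-yl change alters cytotoxicity at all remains open, with no compound shown giving a value inside the measurable range.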